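Saturated ring in place of furan on the pyrrolidine nitrogen

A few compounds are considered here, and "the series" means these few. Any claim that something is new, unique, unknown or untested is made for them only; others in the source may bear on it.

The measured compounds: compound 1 `CN(C(=O)N1CC[C@H](n2cnc3cc(-c4ccc(Cl)cc4)sc3c2=O)C1)[C@H]1CCNC1` with 29 nM; compound 2 `CN(C(=O)N1CC[C@H](n2cnc3cc(-c4ccc(Cl)cc4)sc3c2=O)C1)[C@H]1CCN(C2CCC2)C1` with 9 nM; compound 3 `CN(C(=O)N1CC[C@H](n2cnc3cc(-c4ccc(Cl)cc4)sc3c2=O)C1)[C@H]1CCN(Cc2ccoc2)C1` with 15 nM, all in a functional assay for antagonist activity at melanin-concentrating hormone receptor 1 (Homo sapiens), read by GTPgammaS binding; a higher number here means a weaker inhibitor, a lower number a stronger inhibitor.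

Compound 3 stands second highest of the three numbers, with a 1.7-fold higher number from compound 2 to compound 3 (0.22 log units; within the scatter) and a 1.9-fold lower number from compound 1 to compound 3 (0.29 log units; within the scatter). Compound 4 `CN(C(=O)N1CC[C@H](n2cnc3cc(-c4ccc(Cl)cc4)sc3c2=O)C1)[C@H]1CCN(CC2CCOC2)C1` differs from compound 3 by oxolan-3-yl in place of furan-3-yl on a saturated chain carbon bound to an amine nitrogen in a ring. Among the measured compounds shown here, the steps that bear on this position are a 3.2-fold lower number from compound 1 to compound 2 (0.51 log units; beyond the scatter) and a 1.9-fold lower number from compound 1 to compound 3 (0.29 log units; within the scatter); only the first lies beyond the scatter, and the substituents on that nitrogen move the number little. For compound 4 the expected step is therefore a 1.2-fold lower number from compound 3 to compound 4 (0.06 log units; within the scatter), none beyond the scatter. Compound 4 is estimated at 13 nM, within 5 nM to 35 nM.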

Compound 4, half-maximal inhibitory concentration: 10 nM
Estimate against measurement, compound 4: 1.3-fold (0.11 log units) above; the measured number falls inside the stated range.
By their numbers in this assay, from the lowest: compounds 2, 4, 3 and 1 (each within the scatter of the next, the first and the last beyond it).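

In this assay, the aromatic furan-3-yl ring and the non-aromatic oxolan-3-yl ring on this saturated chain carbon are not told apart (a 1.5-fold lower number from compound 3 to compound 4 (0.18 log units; within the scatter)). The (oxolan-3-yl)methyl group is likewise level with cyclobutyl (a 1.1-fold higher number from compound 2 to compound 4 (0.05 log units; within the scatter)) and, unlike (furan-3-yl)methyl, it clears the scatter against hydrogen on the amine nitrogen in a ring (a 2.9-fold lower number from compound 1 to compound 4 (0.46 log units; beyond the scatter)). Nothing measured here gives a reason for these steps. Going by these compounds, whether a carboxylic acid or a longer chain on that amine nitrogen would keep the number this low remains open.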